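Alkoxy chain removal in aminoglycoside series: cytotoxicity notes

The compounds below may be only part of what the source reports. "The series", "measured", "known", "first", "only" and "open" are said of these compounds alone.

Measured compounds and their numbers in an ADME assay on J774 cells (Mus musculus) for cytotoxicity, read by MTT assay, with a stated time of 24 h, tested at 30 uM; on this read-out higher numbers stand for a weaker effect at the one concentration tested and lower numbers for a stronger effect:
compound 1 `CCCCCCCCCCCO[C@@H]1[C@@H](N)[C@@H](O[C@H]2[C@H](O)[C@@H](O)[C@H](N)C[C@@H]2N)O[C@H](CN)[C@H]1O` gives 77.1%
compound 2 `CCCCCCCCCCCO[C@@H]1[C@@H](O)[C@H](O[C@H]2O[C@H](CN)[C@@H](O)[C@H](OCCCCCCC)[C@H]2N)[C@@H](N)C[C@H]1N` gives 38.8%
compound 3 `CCCCCCCO[C@@H]1[C@@H](N)[C@@H](O[C@H]2[C@H](O)[C@@H](OCCCCCCC)[C@H](N)C[C@@H]2N)O[C@H](CN)[C@H]1O` gives 79.9%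

Compound 3 stands highest of the three numbers, though the gap to compound 1 is within the scatter, so no order between compound 1 and compound 3 can be read from these two values. For the measured compounds named here, the only step beyond the scatter runs a number 41.1 percentage points higher from compound 2 to compound 3 (beyond the scatter), from hydrogen in place of butyl on a saturated chain carbon, seven bonds along the chain from an oxygen on a saturated carbon.

Compound 4 `CCCCCCCO[C@@H]1[C@@H](N)[C@@H](O[C@H]2[C@H](O)[C@@H](O)[C@H](N)C[C@@H]2N)O[C@H](CN)[C@H]1O` is not yet measured. It differs from compound 3 by hydrogen in place of heptyl on an oxygen on a saturated carbon. Going by the values given here, no measured step covers this exact change; the step from compound 2 to compound 3 concerns a different chain at a different oxygen, and compound 1 set against compound 3 shows only that undecyl versus heptyl at the place in question leaves the number essentially unchanged. Among the compounds with values here, the one chain-shortening step pointed upward, so a step upward or none beyond the scatter is expected, a number 5.1 percentage points higher from compound 3 to compound 4 (within the scatter). Compound 4 is therefore estimated at 85%, with a range from 70% to 100%.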

Compound 4, a percentage reported as activity, at one concentration (the size of the read-out at that concentration, not a potency): 70.2%
For compound 4 the middle estimate is 14.8 percentage points above the measured one; the measured number falls inside the stated range.
By their numbers in this assay, from the lowest: compound 2; then compounds 4, 1 and 3 (each within the scatter of the next).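

In this assay, the heptyloxy to hydroxy change at this oxygen on a saturated carbon gives a number 9.7 percentage points lower from compound 3 to compound 4 (within the scatter), so on this core losing the heptyl group does not shift the number beyond the scatter. For the compounds shown here, the large step in this set remains the one involving compound 2, with hydrogen in place of undecyl giving a number 31.4 percentage points higher from compound 2 to compound 4 (beyond the scatter), while compound 3 and compound 4 do not separate from each other. The new compound also shows that shortening the chain does not act alike everywhere, as the step of a number 6.9 percentage points lower from compound 1 to compound 4 (within the scatter) stays within the scatter and does not repeat the large upward step seen on the other core: the same change on two cores in this assay, a number 41.1 percentage points higher (beyond the scatter) from compound 2 to compound 3 and a number 6.9 percentage points lower (within the scatter) from compound 1 to compound 4, 48 percentage points apart, beyond the scatter of two such steps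

The compounds shown leave open whether a chain on only one oxygen, rather than a particular chain length, governs the number, since the heptyl and undecyl groups are compared on just two cores. A chain longer than undecyl, or an amine or carboxylic acid at the place of the heptyl group, could test whether this position tolerates more than the hydroxy and heptyloxy groups seen here.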